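Swapping the Aryl Group on an Amide Nitrogen

This account rests on a few compounds, and the source may have more. Where it says the series, first, only, none or still open, it means among the compounds named here.

Two compounds share one core and differ only in the group carried on an amide-type nitrogen. Compound 1 `CCOC(=O)C1=C(C)NC(C)=C(C(=O)OCC)C1c1ccc(OCC(=O)NCc2ccccc2)cc1` bears a benzyl group there, and in a functional assay on the whole organism (strain Wistar) for inhibition, with Rattus norvegicus as the target, read by paw edema, with stated times of 30 min and 2 h, at a dose of 20 mg/kg (on this read-out lower numbers stand for less inhibition and higher numbers for more inhibition at the one dose given (going by the name of the read-out)), compound 1 gives 8.9%. Compound 2 `CCOC(=O)C1=C(C)NC(C)=C(C(=O)OCC)C1c1ccc(OCC(=O)Nc2c(C)cccc2C)cc1` carries a 2,6-dimethylphenyl group instead, and in this assay compound 2 gives 47.8%. That single exchange produced a number 38.9 percentage points higher from compound 1 to compound 2 (beyond the scatter), so compound 2 stands highest of the two values, with compound 1 well beyond the scatter below it.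

Compound 3 `CCOC(=O)C1=C(C)NC(C)=C(C(=O)OCC)C1c1ccc(OCC(=O)Nc2ccc(C)cc2)cc1` is not yet measured. It differs from compound 2 only in that (4-methylphenyl in place of 2,6-dimethylphenyl on an amide-type nitrogen). Among the compounds with values here, the only measured step that bears on this change is the one from compound 1 to compound 2, and it shows that placing a methyl-bearing phenyl directly on the amide nitrogen, rather than a benzyl group, went with a large rise. Compound 3 keeps a phenyl group directly on that nitrogen, so the estimate for compound 3 stays nearer compound 2 than compound 1, expected as a number 12.8 percentage points lower from compound 2 to compound 3 (beyond the scatter). Compound 3 is therefore estimated at 35% in this assay, with a range from 15% to 55%.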

Compound 3, a percentage reported as inhibition, in the whole organism at one dose (the size of the read-out at that dose, not a potency): 62.2%
Beside the measured number, compound 3's estimate is 27.2 percentage points below it, outside the stated range (above it).
By their numbers in this assay, from the lowest: compound 1; then compound 2; then compound 3.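

Exchanging 2,6-dimethylphenyl for 4-methylphenyl on the amide-type nitrogen gives a number 14.4 percentage points higher from compound 2 to compound 3 (beyond the scatter) in this assay, so the higher values here do not depend on the 2,6-dimethylphenyl group, and the group with one methyl fewer goes further. Set against the benzyl group, the same 4-methylphenyl group gives a number 53.3 percentage points higher from compound 1 to compound 3 (beyond the scatter), which makes compound 3 the highest of these three compounds, with both of its steps beyond the scatter. Nothing available explains why this position responds in this way, so the ranking stands as an observation without a known cause.

The exchange from compound 2 to compound 3 changes both the number of methyl groups and where they sit on the ring, so these compounds cannot show which of the two matters more. A plain phenyl group or a chlorine-bearing phenyl group on the same nitrogen would be needed to show whether the methyl group itself contributes, and each value here describes a single dose, leaving potency across a range of doses open.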